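Replacing the nitrophenyl amide with a tert-butyl isoxazole amide

The source may hold more compounds than are shown below. What is called first, only, known or untested is meant among the compounds shown, and "the series" means these compounds.

Of the compounds shown here, three sharing one core have been measured in an assay on isolated protein for inhibition of Rho-associated protein kinase 2 (Homo sapiens), read by scintillation counting, radiometric assay and 33P incorporation, with a stated time of 40 min, in the presence of a further agent that is not named here; a lower number here means a stronger inhibitor, a higher number a weaker inhibitor. Compound 1 `CCCC(=O)Nc1cccc(NC(=O)COc2ccc3c(=O)ccoc3c2)c1` gives 176 nM, compound 2 `O=C(COc1ccc2c(=O)ccoc2c1)Nc1cccc(NC(=O)c2ccc(Br)cc2)c1` gives 49 nM, and compound 3 `O=C(COc1ccc2c(=O)ccoc2c1)Nc1cccc(NC(=O)c2ccc([N+](=O)[O-])cc2)c1` gives 15 nM, the lowest number of the three; its nearest neighbour is a 3.3-fold lower number from compound 2 to compound 3 (0.51 log units; beyond the scatter) and its furthest is a 12-fold lower number from compound 1 to compound 3 (1.07 log units; beyond the scatter). Compound 4 `CC(C)(C)c1cc(C(=O)Nc2cccc(NC(=O)COc3ccc4c(=O)ccoc4c3)c2)no1` differs from compound 3 in one place: 5-(tert-butyl)-1,2-oxazol-3-yl in place of 4-nitrophenyl on a carbonyl carbon. Within the data shown here, no measured step tests a five-membered aromatic ring with 2 hetero atoms on this carbonyl carbon. Among the measured compounds shown here, the steps that bear on it are a 12-fold lower number from compound 1 to compound 3 (1.07 log units; beyond the scatter) and a 3.6-fold lower number from compound 1 to compound 2 (0.56 log units; beyond the scatter), both moving from propyl to a six-membered aromatic ring of carbon only, and a 3.3-fold lower number from compound 2 to compound 3 (0.51 log units; beyond the scatter), where nitro replaced bromo. Since the nitro group leaves in compound 4, a higher number than compound 3 is expected, of a size between the bromo and propyl analogues. The account therefore expects compound 4 to show 60 nM, between 15 nM and 250 nM, which means an expected step of a 4.0-fold higher number from compound 3 to compound 4 (0.60 log units; beyond the scatter).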

Compound 4, half-maximal inhibitory concentration: 5 nM
The estimate for compound 4 lay 12-fold (1.08 log units) above the measured number; the whole stated range lies above it.
By their numbers in this assay, from the lowest: compound 4; then compound 3; then compound 2; then compound 1.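

In this assay the carbonyl carbon whose other neighbour is an amide-type nitrogen accepts a five-membered aromatic ring with 2 hetero atoms, and neither the six-membered aromatic ring of carbon only nor the nitro group is needed for the lowest number of the series, as shown by a 3.0-fold lower number from compound 3 to compound 4 (0.48 log units; beyond the scatter). The same replacement gives a 9.8-fold lower number from compound 2 to compound 4 (0.99 log units; beyond the scatter) and a 35-fold lower number from compound 1 to compound 4 (1.55 log units; beyond the scatter), so 5-(tert-butyl)-1,2-oxazol-3-yl stands ahead of all three earlier groups at this position. Nothing measured here explains this gain. The compounds shown leave open whether the drop comes with the ring or with the tert-butyl group, since they contain neither a 4-(tert-butyl)phenyl group nor a 5-methyl-1,2-oxazol-3-yl group on this carbonyl carbon. They also leave open how a six-membered ring holding nitrogen, such as a pyridine, would read here.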